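This account rests on a few compounds, and the source may have more. Where it says the series, first, only, none or still open, it means among the compounds named here.

Measured compounds:
Compound 1 `Nc1scc(CN2CCN(c3cccc(C(F)(F)F)c3)CC2)c1C(=O)c1ccc(Cl)cc1` gives -72% in a functional assay on CHO cells with adenosine receptor A1 (Homo sapiens) as the target, read by cAMP accumulation and immunoassay, with a stated time of 6 min, tested at 1 uM; a lower number here means a stronger effect, a higher number a weaker effect of the compound at the concentration tested.
Compound 2 `Nc1scc(CN2CCN(c3ccc(OC(F)(F)F)cc3)CC2)c1C(=O)c1ccc(Cl)cc1` gives -51% in this assay.
Compound 3 `Nc1scc(CN2CCN(c3ccc(C(F)(F)F)cc3)CC2)c1C(=O)c1cccc(C(F)(F)F)c1` gives -27% in this assay.

Compound 3 stands highest of the three numbers, that is, it shows the weakest effect at the concentration tested. Its nearest neighbour is compound 2, whose number is lower by a margin beyond the scatter, and compound 1 lies further still, also beyond the scatter. Compound 1 and compound 3 differ in two places, so their values are only compared, not traced to a single change.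

The unmeasured compound 4 `Nc1scc(CN2CCN(c3c(F)cccc3F)CC2)c1C(=O)c1cccc(C(F)(F)F)c1` departs from compound 3 by one change: 2,6-difluorophenyl in place of 4-(trifluoromethyl)phenyl on an amine nitrogen in a ring.

Within the data shown here, only one measured step bears on this change, since it also swaps the group on the amine nitrogen in the ring: a number 21 percentage points higher from compound 1 to compound 2 (beyond the scatter). Among the measured compounds shown here, that step shows that exchanging this group moves the number by a modest amount, but only one such exchange is known and its direction need not carry over to a different pair of groups. A modest shift in either direction, or none beyond the scatter, is therefore expected for compound 4, and the estimate is kept near the value of compound 3, with a step of a number 3 percentage points lower from compound 3 to compound 4 (within the scatter) expected. Compound 4 is expected to give about -30% in this assay, within a range from -60% to 0%.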

Compound 4, a percentage reported as activity, at one concentration (the size of the read-out at that concentration, not a potency): 1.3%
Compound 4: the middle estimate sits 31.3 percentage points below what was measured; measured number outside the range, above it.
By their numbers in this assay, from the lowest: compound 1; then compound 2; then compound 3; then compound 4.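

In this assay, replacing the group on the amine nitrogen in the ring does more than shift the number a little: a number 28.3 percentage points higher from compound 3 to compound 4 (beyond the scatter), with 2,6-difluorophenyl in place of 4-(trifluoromethyl)phenyl. Compound 3 gives -27%, a clear negative number, whereas compound 4 gives 1.3%, so this single exchange is enough to take the number to about zero at the concentration tested. This is a second exchange at this position to raise the number, after a number 21 percentage points higher from compound 1 to compound 2 (beyond the scatter), and it shows the same direction with a different group on the carbonyl and a different pair of aryl groups on the nitrogen, though two steps are too few to establish a rule.

No measurement shown here accounts for the step. Compound 4 differs from compound 3 both in losing the trifluoromethyl group and in gaining two fluorines, so the compounds shown cannot separate these two parts of the change, and how an unsubstituted phenyl or a pyridine ring on the same nitrogen would read remains open.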